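The source may report more compounds than this note shows. Statements on the series, on what has been measured and on what is new or still open speak of the compounds shown alone.

Measured compounds:
- compound 1, `CCCCCCCCc1ccc(OCC(=O)Cn2nnc(-c3cccc(C(=O)OC)c3)n2)cc1`: 34 nM
- compound 2, `CCCCCCCCc1ccc(OCC(=O)Cn2nnnc2-c2ccc(Cl)cc2)cc1`: 130 nM

Both numbers come from an assay on microsomes from brain for inhibition of Fatty-acid amide hydrolase 1 (Rattus norvegicus), read by fluorescence and HPLC, with a stated time of 60 min; a higher number here means a weaker inhibitor, a lower number a stronger inhibitor. Of the two, compound 2 carries the higher number, and the gap to compound 1 falls beyond the usual scatter, so compound 2 reads as the weaker inhibitor of the pair. Going by the values given here, no single-change pair connects the two, since their aryl groups sit on different positions of the shared core, so the two values show only the gap itself.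

Compound 3, `CCCCCCCCc1ccc(OCC(=O)Cn2nnnc2-c2ccc(C(=O)O)cc2)cc1`, is the untested one. It departs from compound 2 by one change: carboxy in place of chloro on an aromatic carbon The chloro leaves and a carboxy enters, bringing one hydrogen-bond donor and one hydrogen-bond acceptor to the ring of carbon only.

Among the compounds with values here, no measured step of this kind exists in the set, so the expectation rests on compound 2 alone. The step from compound 2 to compound 3 is expected to move toward a weaker inhibitor, on the order of a 3.1-fold higher number from compound 2 to compound 3 (0.49 log units; beyond the scatter), with wide uncertainty. Compound 3 is estimated at 400 nM in this assay, within a range of 100 nM to 2000 nM.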

Compound 3, half-maximal inhibitory concentration: 3400 nM
Compound 3: middle estimate off by 8.5-fold (0.93 log units), on the low side, outside the stated range (above it).
By their numbers in this assay, from the lowest: compound 1; then compound 2; then compound 3.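

Carboxy in place of chloro, on the six-membered aromatic ring of carbon only and para to a large group, gives a 26-fold higher number from compound 2 to compound 3 (1.42 log units; beyond the scatter) in this assay and is the first single-change step in the series. It shows that the value responds strongly to the group at this position, and that 4-carboxyphenyl lies well on the weaker side of 4-chlorophenyl. Nothing on hand accounts for the size of this step.

Still open, going by these compounds, is whether this step belongs to the carboxylic acid itself or would also appear with a carboxamide or a nitrile in the same position. Also open, on these data alone, is how a carboxylic acid would read on the core of compound 1, where the aryl group sits at a different position.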